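The source may hold more compounds than are shown below. What is called first, only, known or untested is meant among the compounds shown, and "the series" means these compounds.

The series shares one core, seen in compound 1 `CCOC(=O)[C@H](CCC(=O)O)NC(=O)c1ccc(Sc2nc3cc(N)cc(N)c3nc2-c2ccccc2)cc1`, compound 2 `Nc1cc(N)c2nc(-c3ccccc3)c(Sc3ccc(F)cc3)nc2c1` and compound 3 `COc1cc(CNc2nc3cc(N)cc(N)c3nc2-c2ccccc2)cc(OC)c1OC`. In a functional assay on K562 cells (Homo sapiens) for inhibition, read by sulforhodamine B assay, with a stated time of 48 h (a higher number here means a weaker inhibitor of growth, a lower number a stronger inhibitor of growth), compound 1 gives 24500 nM. In this assay compound 2 gives 38900 nM, the highest of the two numbers shown; the nearest is compound 1, whose number is lower by a margin that stays within the scatter, so the two cannot be placed in any order. Compound 3 gives only a limit in this assay, namely < 50200 nM, and so stands apart from the numbers (the limit of < 50200 nM in this assay, at which 1 of the 3 values shown sits).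

Compound 4 `Nc1cc(N)c2nc(-c3ccccc3)c(NCc3ccc(F)cc3)nc2c1` has not yet been measured. It follows compound 2 through one change, ((4-fluorobenzyl)amino in place of (4-fluorophenyl)sulfanyl on an aromatic carbon). The leaving group carries no hydrogen-bond donor, the entering (4-fluorobenzyl)amino group one, and the entering group is one heavy atom larger. Going by the values given here, no measured pair in the set differs by a single change, so no measured step shows what such a swap does in this assay; the only other amino-linked compound, compound 3, gives a limit rather than a number. The step is therefore expected to be small, with no direction beyond the scatter, a 1.1-fold lower number from compound 2 to compound 4 (0.05 log units; within the scatter). Compound 4 is estimated to give 35000 nM in this assay, between 12000 nM and 90000 nM.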

Compound 4, concentration for total growth inhibition: < 100000 nM
Compound 4 was reported as a limit (the forecaster's own chance of this, stated with the estimate: 30%); the middle value is on the limit's open side.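

Compound 4 gives only a limit in this assay, < 100000 nM, so the step from compound 2 to compound 4 cannot be read. The compounds shown leave open whether (4-fluorobenzyl)amino in place of (4-fluorophenyl)sulfanyl on an aromatic carbon changes growth inhibition at all, or in which direction.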